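This account rests on a few compounds, and the source may have more. Where it says the series, first, only, none or still open, it means among the compounds named here.

Measured compounds:
- compound 1, `N=C(Nc1cccc(C(F)(F)F)c1)c1cc2c(-c3ccccc3)n[nH]c2cn1`, giving 22300 nM in a functional assay on MDA-MB-231 cells (Homo sapiens) for cytotoxicity, read by MTT assay, with a stated time of 72 h; a higher number here means a weaker inhibitor, a lower number a stronger inhibitor
- compound 2, `Cn1nc(-c2ccccc2)c2cc(C(=N)Nc3ccccc3)ncc21`, giving 11100 nM in this assay
- compound 3, `COc1ccc(Cn2nc(-c3ccccc3)c3cc(C(=N)Nc4ccccc4)ncc32)cc1`, giving 5400 nM in this assay

Among these three, compound 2 stands second highest. Compound 1, which carries the trifluoromethyl on the aniline ring but no methyl on the ring nitrogen, and compound 2 lie within the scatter of one another, so nothing can be said about their order. Compound 3 sits beyond the scatter, and the step of a 2.1-fold lower number from compound 2 to compound 3 (0.31 log units; beyond the scatter) is modest.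

Compound 4, `Cn1nc(-c2ccccc2)c2cc(C(=N)Nc3cccc(C(F)(F)F)c3)ncc21`, arises from compound 2 through one change: trifluoromethyl in place of hydrogen on an aromatic carbon. Within the data shown here, no measured step covers this change. Among the measured compounds shown here, the only step on record, from compound 2 to compound 3, alters a different position and does not bear on it. The pair compound 1 and compound 2 differs at two places and shows values within the scatter. Compound 4 is therefore expected to change by a 1.0-fold lower number from compound 2 to compound 4 (0.00 log units; within the scatter), which is no step beyond the scatter. The estimate for compound 4 is 11000 nM, between 4000 nM and 30000 nM.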

Compound 4, half-maximal inhibitory concentration: 21400 nM
The estimate for compound 4 lay 1.9-fold (0.29 log units) below the measured number, and the stated range covers the measured number.
By their numbers in this assay, from the lowest: compound 3; then compounds 2, 4 and 1 (each within the scatter of the next).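

In this assay, the trifluoromethyl in place of hydrogen on an aromatic carbon, meta to a large group, gives a 1.9-fold higher number from compound 2 to compound 4 (0.29 log units; within the scatter) and so cannot be told apart from the hydrogen at this position. Among these compounds, the methyl in place of hydrogen on an aromatic nitrogen, until now tied up with a second difference, can be read alone for the first time and gives a 1.0-fold lower number from compound 1 to compound 4 (0.02 log units; within the scatter), so neither single change separates its pair. Nothing available explains these numbers.

From the compounds shown here alone, whether an amine or a carboxylic acid on that same aromatic carbon would give a step beyond the scatter remains open. So does whether a longer chain on the aromatic nitrogen would do so, and whether the 4-methoxyphenyl step seen without trifluoromethyl would hold with it present.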